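The source may hold more compounds than are shown below. What is called first, only, known or untested is meant among the compounds shown, and "the series" means these compounds.

Compound 3 `COc1cc(C2CC(c3cc(OC)c(OC)c(OC)c3)=NN2C(C)=O)ccc1OCc1cn(Cc2ccc([N+](=O)[O-])cc2)nn1` stands highest of the three numbers in a functional assay on COLO 205 cells (Homo sapiens) for inhibition, read by sulforhodamine B assay, tested at 100 uM (on this read-out lower numbers stand for less inhibition of growth and higher numbers for more inhibition of growth at the one concentration tested), where compound 3 gives 99%. Compound 1 `COc1cc(C2CC(c3ccc(Br)cc3)=NN2C(C)=O)ccc1OCc1cn(Cc2ccc([N+](=O)[O-])cc2)nn1` gives 47% in this assay, and compound 2 `COc1cc(C2CC(c3ccccc3)=NN2C(C)=O)ccc1OCc1cn(Cc2ccc([N+](=O)[O-])cc2)nn1` gives 11%. All three steps between them lie beyond the scatter: a number 52 percentage points higher from compound 1 to compound 3 (beyond the scatter), a number 88 percentage points higher from compound 2 to compound 3 (beyond the scatter), and a number 36 percentage points lower from compound 1 to compound 2 (beyond the scatter).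

Compound 4 `COc1ccc(C2=NN(C(C)=O)C(c3ccc(OCc4cn(Cc5ccc([N+](=O)[O-])cc5)nn4)c(OC)c3)C2)cc1` is not yet measured. Its difference from compound 3 is 4-methoxyphenyl in place of 3,4,5-trimethoxyphenyl on a carbon with a double bond to nitrogen. Among the compounds with values here, two measured steps bear on this change, both of which exchange the group on the carbon with a double bond to nitrogen for the 3,4,5-trimethoxyphenyl group: a number 88 percentage points higher from compound 2 to compound 3 (beyond the scatter) and a number 52 percentage points higher from compound 1 to compound 3 (beyond the scatter). Both were large and upward, so the 3,4,5-trimethoxyphenyl group accounts for most of the growth inhibition seen in compound 3; compound 4 keeps only a single methoxy on that phenyl, and the step is read as a move back in the other direction. A large downward step in this assay is therefore expected, though the remaining methoxy group leaves it open whether compound 4 falls as far as compound 2 at 11%.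

For compound 4 the expected value in this assay is 50%, with a range from 20% to 85%. The step this estimate means, a number 49 percentage points lower from compound 3 to compound 4 (beyond the scatter), is expected to lie beyond the scatter.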

Compound 4, percent growth inhibition at one concentration: 75%
Compound 4: the middle estimate sits 25 percentage points below what was measured, and the stated range covers the measured number.
By their numbers in this assay, from the lowest: compound 2; then compound 1; then compound 4; then compound 3.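

In this assay, the methoxy group alone accounts for a large share of the rise at this position: there is a number 64 percentage points higher from compound 2 to compound 4 (beyond the scatter) on placing methoxy where hydrogen stood, while cutting 3,4,5-trimethoxyphenyl back to 4-methoxyphenyl gives only a number 24 percentage points lower from compound 3 to compound 4 (beyond the scatter) and keeps much of the growth inhibition. Within the data shown here, the identity of the single group on the phenyl also matters, with a number 28 percentage points higher from compound 1 to compound 4 (beyond the scatter) when methoxy replaces bromo, so the order of the four compounds is not set by substitution as such. Nothing on hand accounts for these differences.

Still open, from the compounds shown here alone, is whether methoxy is needed as such, or whether an ethoxy, a hydroxy or a dimethylamino group on the same phenyl would give a similar number, and how a phenyl with an intermediate count of methoxy groups would fall between compound 4 and compound 3. All four numbers also come from one concentration, so they leave open how the compounds would rank across a range of concentrations.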